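The source may hold more compounds than are shown below. What is called first, only, known or untested is meant among the compounds shown, and "the series" means these compounds.

In an ADME assay (liver) for metabolic stability, with Liver microsome (Rattus norvegicus) as the target, using microsomes and NADPH, with a stated time of 30 min, tested at 1 uM (a lower number here means slower removal, a higher number faster removal of the compound), compound 1 `Nc1ccc(S(=O)(=O)N2CCN(c3ncc(C(O)(C(F)(F)F)C(F)(F)F)cc3C3CC3)CC2)cn1` gives 27 mL.min-1.g-1 and compound 2 `Nc1ccc(S(=O)(=O)N2CCN(c3ncc(C(O)(C(F)(F)F)C(F)(F)F)cc3C#CCO)CC2)cn1` gives 65 mL.min-1.g-1 while compound 3 `COCC#Cc1cc(C(O)(C(F)(F)F)C(F)(F)F)cnc1N1CCN(S(=O)(=O)c2ccc(N)nc2)CC1` gives 399 mL.min-1.g-1 as the highest of the three numbers. Among the compounds with values here, compound 4 `CCn1cc(-c2cc(C(O)(C(F)(F)F)C(F)(F)F)cnc2N2CCN(S(=O)(=O)c3ccc(N)nc3)CC2)cn1` has 1-ethyl-1H-pyrazol-4-yl in place of 3-methoxyprop-1-yn-1-yl on an aromatic carbon and no measured step makes this exact replacement. The nearest evidence is a large step, a 15-fold higher number from compound 1 to compound 3 (1.17 log units; beyond the scatter) and two modest ones, a 2.4-fold higher number from compound 1 to compound 2 (0.38 log units; beyond the scatter) and a 6.1-fold higher number from compound 2 to compound 3 (0.79 log units; beyond the scatter) within the same short series. Within the data shown here, compound 3 alone carries 3-methoxyprop-1-yn-1-yl, so a modest step to a lower number is expected in this assay although the series holds no direct precedent for the entering group. The expected change is a 3.6-fold lower number from compound 3 to compound 4 (0.56 log units; beyond the scatter) on this estimate. For compound 4 the estimated value is 110 mL.min-1.g-1 within an expected range of 35 mL.min-1.g-1 to 320 mL.min-1.g-1 for this read-out.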

Compound 4, intrinsic clearance in microsomes: 194 mL.min-1.g-1
Compound 4: middle estimate off by 1.8-fold (0.25 log units), on the low side, within the range that was stated.
By their numbers in this assay, from the lowest: compound 1; then compound 2; then compound 4; then compound 3.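

In this assay, 1-ethyl-1H-pyrazol-4-yl, the first aromatic ring at this position, gives a 2.1-fold lower number from compound 3 to compound 4 (0.31 log units; beyond the scatter) but also a 3.0-fold higher number from compound 2 to compound 4 (0.47 log units; beyond the scatter) and a 7.2-fold higher number from compound 1 to compound 4 (0.86 log units; beyond the scatter) and so falls inside the span of the earlier groups. A group without a triple bond therefore stands above compound 2, which has one, and the number does not follow the triple bond alone. Nothing on hand explains this order of the groups.
On these data alone, whether the number follows the ethyl group or the pyrazole ring itself stays open. A 1-methyl-1H-pyrazol-4-yl group at this position would separate the two.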